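The source may hold more compounds than are shown below. What is called first, only, known or untested is meant among the compounds shown, and "the series" means these compounds.

Series notes, HepG2 cell inhibition

All measured values come from a functional assay on HepG2 cells (Homo sapiens) for inhibition, read by MTT assay, with a stated time of 72 h; a lower number here means a stronger inhibitor, a higher number a weaker inhibitor.

Compound 1, `Cc1noc(C)c1-c1cnc(N)c(Oc2ccc(C(=O)Nc3ccccc3Cl)cc2)n1`: > 100000 nM, a limit of the assay, not a number.
Compound 2, `Cn1cc(-c2cnc(N)c(Oc3ccc(C(=O)Nc4ccccc4Cl)cc3)n2)cn1`: 66900 nM.
Compound 3, `Cc1noc(C)c1-c1cnc(N)c(NCc2ccc(C(=O)Nc3ccc(Cl)cc3)cc2)n1`: > 100000 nM, a limit of the assay, not a number.

Compound 1 and compound 2 share a core and differ in one place: 1-methyl-1H-pyrazol-4-yl in place of 3,5-dimethyl-1,2-oxazol-4-yl on an aromatic carbon. The step is an at least 1.4-fold lower number from compound 1 to compound 2 (0.17 log units; that floor lies within the scatter). Its size cannot be fixed, because the limit of > 100000 nM in this assay, at which 2 of the 3 values shown sit, sits at the value of compound 1; only the floor of the step is known, and that floor lies within the scatter of this assay.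

Compound 3 carries a different core; the difference between the core of compound 1 and the core of compound 3 is not broken down here. Compound 3 reports only a limit in this assay.

Compound 4, `Cn1cc(-c2cnc(N)c(NCc3ccc(C(=O)Nc4ccc(Cl)cc4)cc3)n2)cn1`, is not yet measured. It differs from compound 3 by 1-methyl-1H-pyrazol-4-yl in place of 3,5-dimethyl-1,2-oxazol-4-yl on an aromatic carbon, the same change as from compound 1 to compound 2, at a place described in the same words. Given that compound 3 sits at the limit and that the only measured instance of this change moved compound 1 to compound 2 by an at least 1.4-fold lower number from compound 1 to compound 2 (0.17 log units; that floor lies within the scatter), the expected step is an at least 1.1-fold lower number from compound 3 to compound 4 (0.04 log units; that floor lies within the scatter). Compound 4 is therefore expected to come out around 90000 nM in this assay, estimated to lie between 40000 nM and 200000 nM, with a fair chance that the assay again reports only a limit.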

Compound 4, half-maximal inhibitory concentration: 20100 nM
Estimate against measurement, compound 4: 4.5-fold (0.65 log units) above, and the stated range ends above it.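

In this assay, 1-methyl-1H-pyrazol-4-yl in place of 3,5-dimethyl-1,2-oxazol-4-yl on the aromatic carbon gives an at least 4.9-fold lower number from compound 3 to compound 4 (0.69 log units; beyond the scatter), so on this core even the floor of the step clears the scatter. Both steps of this change run toward a lower number, which is as much as two cores can show, and their sizes cannot be set against each other: the same change on two cores in this assay, an at least 1.4-fold lower number (0.17 log units; that floor lies within the scatter) from compound 1 to compound 2 and an at least 4.9-fold lower number (0.69 log units; beyond the scatter) from compound 3 to compound 4; the limit leaves it open whether they differ Neither step has a fixed size, as each starts from a compound that reports only a limit, and the change therefore cannot be treated as a transferable increment of known size: the limit of > 100000 nM in this assay, at which 2 of the 4 values shown sit.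

Still open, on these data alone, is how large the step really is on either core, and whether it runs the same way on any core beyond these two; what separates the core of compound 1 from the core of compound 3 is not broken down, so nothing here assigns a share of the result to any part of that difference. Also open, as far as these compounds go, is what a smaller or differently charged group, such as a carboxylic acid or an amine, would give on the same aromatic carbon in this assay.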